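Benzyl amide variation on the aspartyl core

The compounds below may be only part of what the source reports. "The series", "measured", "known", "first", "only" and "open" are said of these compounds alone.

The two measured compounds of this set share one core and differ only in the aryl group on the benzyl amide. Compound 1 `C[C@H](NC(=O)C(=O)NCc1ccc(Cl)cc1)C(=O)N[C@@H](CC(=O)O)C(=O)COc1c(F)c(F)cc(F)c1F` carries a 4-chlorophenyl there and gives in a functional assay on Jurkat cells (Homo sapiens) (a lower number here means a stronger inhibitor, a higher number a weaker inhibitor), a value of 8.4 nM. Compound 2 `Cc1ccccc1CNC(=O)C(=O)N[C@@H](C)C(=O)N[C@@H](CC(=O)O)C(=O)COc1c(F)c(F)cc(F)c1F` carries a 2-methylphenyl instead and gives in this assay a value of 52 nM. Among the measured compounds shown here, compound 2 thus stands highest of the two numbers; the only step available, a 6.2-fold higher number from compound 1 to compound 2 (0.79 log units; beyond the scatter), is modest but beyond the scatter.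

Compound 3 `Cc1ccc(CNC(=O)C(=O)N[C@@H](C)C(=O)N[C@@H](CC(=O)O)C(=O)COc2c(F)c(F)cc(F)c2F)cc1C` has not yet been measured. It differs from compound 2 as follows: 3,4-dimethylphenyl in place of 2-methylphenyl on a saturated chain carbon bound to an amide-type nitrogen. The step from compound 1 to compound 2 bears on this change, since it is a variation at the same saturated chain carbon bound to an amide-type nitrogen; it showed a modest loss when 2-methylphenyl replaced 4-chlorophenyl. With a single relevant step, the direction for 3,4-dimethylphenyl is uncertain, and a step of modest size toward a lower number or none beyond the scatter is expected, a 2.1-fold lower number from compound 2 to compound 3 (0.32 log units; beyond the scatter). For compound 3 the estimated value in this assay is 25 nM, within a range of 8 nM to 80 nM.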

Compound 3, half-maximal inhibitory concentration: > 10000 nM
Compound 3: no number, only a limit; the forecaster's own chance of this, stated with the estimate: 2%; middle value at least 400-fold (2.60 log units) away from the limit.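

In this assay compound 3 gives no number, only a limit of the assay: the limit of > 10000 nM in this assay, at which 1 of the 3 values shown sits.

The change to 3,4-dimethylphenyl on a saturated chain carbon bound to an amide-type nitrogen amounts to an at least 190-fold higher number from compound 2 to compound 3 (2.28 log units; beyond the scatter), and the comparison with the 4-chlorophenyl compound amounts to an at least 1100-fold higher number from compound 1 to compound 3 (3.07 log units; beyond the scatter). The earlier pair suggested a modest spread at this place, whereas compound 3 shows that it does not accept every aryl group: the entering and leaving groups carry the same ring, the same donor and acceptor counts and no net charge, and differ in heavy atoms only as 8 against 7, yet the step is large.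

The compounds shown do not tell whether the loss belongs to the 3,4-dimethylphenyl group as a whole or to one of its two methyl groups, which a comparison with 3-methylphenyl and 4-methylphenyl would separate. As far as these compounds go, how far compound 3 lies beyond its limit and what causes the step also remain open.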